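Benzyl amide of the hydroxylamino pyranone: expected cytotoxicity

The source may report more compounds than this note shows. Statements on the series, on what has been measured and on what is new or still open speak of the compounds shown alone.

Measured compounds:
- compound 1, `Cc1ccc(NC(=O)c2c(NO)cc(-c3ccc(F)cc3)oc2=O)cc1`, in an ADME assay on Huh-7 cells (Homo sapiens) for cytotoxicity, read by a luciferase reporter and WST assay, with a stated time of 3 days (on this read-out higher numbers stand for lower toxicity in this test and lower numbers for higher toxicity in this test), compound 1 gives > 20000 nM, a limit of the assay.
- compound 2, `CNC(=O)c1c(NO)cc(-c2ccc(F)cc2)oc1=O`, in this assay compound 2 gives > 20000 nM, a limit.
- compound 3, `COC(=O)CNC(=O)c1c(NO)cc(-c2ccc(F)cc2)oc1=O`, in this assay compound 3 gives > 20000 nM, a limit.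

Going by the values given here, compound 3 stands where every value so far stands: at the limit of > 20000 nM in this assay, at which 3 of the 3 values shown sit, so no number separates it from the others. The step to compound 4, `O=C(NCc1ccccc1)c1c(NO)cc(-c2ccc(F)cc2)oc1=O`, is phenyl in place of methoxycarbonyl on a saturated chain carbon bound to an amide-type nitrogen. Among the compounds with values here, three measured steps bear on changes at the same amide-type nitrogen: a step that the two limits leave unreadable from compound 1 to compound 2, a step that the two limits leave unreadable from compound 1 to compound 3 and a step that the two limits leave unreadable from compound 2 to compound 3. None of them yields a readable size, since both ends sit at the limit, so they give no direction and no size, only the observation that three different groups on this nitrogen all left the compounds at the limit. Compound 4 is therefore expected to give 30000 nM, with a range from 10000 nM to 100000 nM, and the expected step is a step that the limit leaves unreadable from compound 3 to compound 4, most likely again a limit rather than a number.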

Compound 4, half-maximal cytotoxic concentration: > 20000 nM
Compound 4 ended at the assay's limit (the forecaster's own chance of this, stated with the estimate: 80%); the middle value is on the limit's open side.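

No step linking compound 4 to compound 1, compound 2 or compound 3 can be read, because both ends of each step sit at a limit and not at a number: the limit of > 20000 nM in this assay, at which 4 of the 4 values shown sit.

The compounds shown leave open whether the groups on the amide-type nitrogen differ at all in this assay, since none of these compounds gives a number to compare.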